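Working notes: compound 2 to compound 3

The source may hold more compounds than are shown below. What is called first, only, known or untested is meant among the compounds shown, and "the series" means these compounds.

Measured in an ADME assay on PANC-1 cells (Homo sapiens) for cytotoxicity, read by MTT assay; a higher number here means that more compound is tolerated, a lower number that less compound is tolerated:
- compound 1 `Cc1nc(-c2cccnc2)sc1-c1nnc(-c2ccc([N+](=O)[O-])cc2)o1`: > 100 ug/mL
- compound 2 `Cc1cccc(-c2nnc(-c3sc(-c4cccnc4)nc3C)o2)c1`: > 100 ug/mL

Compound 1 gives > 100 ug/mL, which is a limit of this assay and not a number. Compound 2 gives > 100 ug/mL, which is likewise a limit and not a number. The whole record so far is the limit of > 100 ug/mL in this assay, at which 2 of the 2 values shown sit. Within the data shown here, neither compound has a numerical value, so no order can be read between them, and the series offers no measured step.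

The next compound is compound 3 `Cc1nc(-c2cccnc2)sc1-c1nnc(-c2ccc(O)cc2)o1`. It carries 4-hydroxyphenyl in place of 3-methylphenyl on an aromatic carbon.

The expectation for this change rests only on (the limit of > 100 ug/mL in this assay, at which 2 of the 2 values shown sit). No step beyond the usual scatter is expected, and no direction can be assigned. The expected step is a step that the limit leaves unreadable from compound 2 to compound 3. A report of only a limit is also expected to be the likeliest outcome for compound 3 in this assay. For compound 3 the estimated value is 110 ug/mL, with an expected range from 50 ug/mL to 200 ug/mL.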

Compound 3, half-maximal cytotoxic concentration: > 100 ug/mL
Compound 3: no number, only a limit; the forecaster's own chance of this, stated with the estimate: 70%; the middle value does not contradict the limit.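

In this assay compound 3 gives > 100 ug/mL, a limit and not a number. No step can be read between compound 3 and compound 1 or compound 2, because the record remains entirely at the limit: the limit of > 100 ug/mL in this assay, at which 3 of the 3 values shown sit.

The compounds shown leave open whether the groups on the shared core differ at all in this assay.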